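The source may hold more compounds than are shown below. What is called first, only, known or untested is meant among the compounds shown, and "the series" means these compounds.

Measured in an ADME assay on J774 cells (Mus musculus) for cytotoxicity (a higher number here means that more compound is needed for the effect, a lower number that less compound is needed), so far:
compound 1, `CCCCCCCc1c(C)nc2cc(OC)ccc2c1O`, gives > 34800 nM
compound 2, `CCCCCCCc1c(C)nc2ccccc2c1O`, gives 5100 nM
compound 3, `CCCCC#Cc1c(C)[nH]c2ccc(OC)cc2c1=O`, gives > 36800 nM

The value of compound 1 is a limit of this assay, not a number: the limit of > 34800 nM in this assay, at which 1 of the 3 values shown sits. The value of compound 3 is likewise a limit: the limit of > 36800 nM in this assay, at which 1 of the 3 values shown sits. Only compound 2 gives a number in this assay.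

The change from compound 1 to compound 2 is hydrogen in place of methoxy on an aromatic carbon. It produced an at least 6.8-fold lower number from compound 1 to compound 2 (0.83 log units; beyond the scatter).

Compound 4, `CCCCC#Cc1c(C)[nH]c2ccccc2c1=O`, is not yet measured in this assay. It differs from compound 3 by the same change, (hydrogen in place of methoxy on an aromatic carbon). The two place lines agree word for word, so this is the same change, made a second time in the series. How the core of compound 3 differs from the core of compound 1 is not broken down here.

Since compound 3 sits at a limit, the step to compound 4 is expected to be an at least 2.4-fold lower number from compound 3 to compound 4 (0.38 log units; beyond the scatter), resting on the earlier step of an at least 6.8-fold lower number from compound 1 to compound 2 (0.83 log units; beyond the scatter) from compound 1. Compound 4 is expected to land near 15000 nM, between 4000 nM and 60000 nM, with a fair chance that this assay again reports only a limit for compound 4.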

Compound 4, half-maximal effective concentration: 8900 nM
Compound 4: the middle estimate sits 1.7-fold (0.23 log units) above what was measured; low and high end bracket the measured number.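

In this assay, hydrogen in place of methoxy on an aromatic carbon gives an at least 4.1-fold lower number from compound 3 to compound 4 (0.61 log units; beyond the scatter), so the change runs the same way on the second core as on the first. Set side by side, the two steps on the two cores read: the same change on two cores in this assay, an at least 6.8-fold lower number (0.83 log units; beyond the scatter) from compound 1 to compound 2 and an at least 4.1-fold lower number (0.61 log units; beyond the scatter) from compound 3 to compound 4; the limit leaves it open whether they differ

The value of compound 3, > 36800 nM, is a limit of this assay and not a number, so the step fixes a direction and a minimum size on this core, not its true size, and two cores do not show that the change will carry to further cores.

Still open, on these data alone, is how groups other than methoxy and hydrogen, such as a fluorine or chlorine atom, an amine or a carboxylic acid, would read at this place in this assay. Among the compounds shown here, the effect of the core itself also remains unresolved: compound 2 and compound 4 differ in more than one place, and no single step between them can be read.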